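Replacing the 3,4-dichlorophenyl group of compound 3

The source may hold more compounds than are shown below. What is called first, only, known or untested is meant among the compounds shown, and "the series" means these compounds.

In an ADME assay on microsomes from liver (Rattus norvegicus) for metabolic stability, read by LC-MS, using NADPH, at 37 degrees C (on this read-out higher numbers stand for a longer-lived compound and lower numbers for a shorter-lived compound), compound 3 (`Cc1oc(-c2ccc(Cl)c(Cl)c2)nc1CN1CCC(C(=O)NCCCN2C[C@H](C)C[C@H](C)C2)CC1`) gives > 0.5 h, which is a limit of the assay and not a number. Compound 1 (`Cc1cc(C)c(-c2nc(CN3CCC(C(=O)NCCCN4C[C@H](C)C[C@H](C)C4)CC3)c(C)o2)c(C)c1`) gives > 0.5 h, which is also a limit. Compound 2 (`Cc1oc(-c2ccccc2Cl)nc1CN1CCC(C(=O)NCCCN2C[C@H](C)C[C@H](C)C2)CC1`) gives a true number, 0.25 h. Compound 4 (`Cc1oc(-c2c(F)cccc2F)nc1CN1CCC(C(=O)NCCCN2C[C@H](C)C[C@H](C)C2)CC1`) differs from compound 3 in one place: 2,6-difluorophenyl in place of 3,4-dichlorophenyl on an aromatic carbon. By name, the 2-chlorophenyl group of compound 2 is the closest match to the entering group, so the most relevant measured step is an at least 2.0-fold higher number from compound 2 to compound 3 (0.30 log units; that floor lies within the scatter). Also relevant is an at least 2.0-fold lower number from compound 1 to compound 2 (0.30 log units; that floor lies within the scatter). Both sizes are only floors. A modest fall in this assay is therefore expected, possibly no larger than the scatter, with an estimated at least 1.4-fold lower number from compound 3 to compound 4 (0.15 log units; that floor lies within the scatter). The expected half-life of compound 4 is 0.35 h, with an estimated range from 0.15 h to 0.8 h.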

Compound 4, half-life: 0.35 h
Estimate against measurement, compound 4: no gap at the digits printed; measured number inside the range.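

With 2,6-difluorophenyl, this position gains a second true number in this assay, and the two groups with true numbers can be compared directly: a 1.4-fold higher number from compound 2 to compound 4 (0.15 log units; within the scatter), so 2,6-difluorophenyl and 2-chlorophenyl cannot be told apart here. The other two steps, an at least 1.4-fold lower number from compound 3 to compound 4 (0.15 log units; that floor lies within the scatter) and an at least 1.4-fold lower number from compound 1 to compound 4 (0.15 log units; that floor lies within the scatter), are only floors. Their true size cannot be read because of one limit: the limit of > 0.5 h in this assay, at which 2 of the 4 values shown sit.

Going by these compounds, how far the 3,4-dichlorophenyl and 2,4,6-trimethylphenyl compounds lie beyond that limit stays open. So does whether a phenyl ring carrying an amine or a carboxylic acid would change the half-life at this position.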